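This account rests on a few compounds, and the source may have more. Where it says the series, first, only, none or still open, it means among the compounds named here.

Measured so far in an assay on cell membranes for displacement of a labelled ligand from Cholecystokinin receptor type A (Rattus norvegicus), read by CCK-8 assay, with a stated time of 2 h; on this read-out lower numbers stand for stronger inhibition and higher numbers for weaker inhibition:
compound 1 `CN1C(=O)C=C(Cl)C1(O)c1ccc(Cl)cc1` gives 2000 nM
compound 2 `O=C1C=C(Cl)C(O)(c2ccc(Cl)cc2)N1C1CC1` gives 4000 nM
compound 3 `CCCCCCN1C(=O)C=C(Cl)C1(O)c1ccccc1` gives 4500 nM

Compound 3 carries the highest of the three numbers; its gap to compound 2 stays within the scatter, while its gap to compound 1 lies beyond it. For the measured compounds named here, the only step that can be read cleanly within this set is a 2.0-fold higher number from compound 1 to compound 2 (0.30 log units; within the scatter), which concerns the group on the ring nitrogen and stays within the scatter.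

The next member is compound 4 `CCCCCCN1C(=O)C=C(Cl)C1(O)c1ccc(Cl)cc1`. It differs from compound 3 by chloro in place of hydrogen on an aromatic carbon. Going by the values given here, no measured pair differs by this change alone: compound 1 and compound 2 both carry the chloro group, but they also differ from compound 3 in the group on the ring nitrogen, so they give no clean reading of the step. Still, in this assay compound 1 gives 2000 nM and compound 2 gives 4000 nM, while compound 3 gives 4500 nM; the first two numbers sit at or somewhat below that of compound 3, which suggests at most a modest move toward lower numbers once the chloro group is added.

The expected step is therefore a 1.5-fold lower number from compound 3 to compound 4 (0.18 log units; within the scatter), a shift that need not clear the scatter. For compound 4 the estimate in this assay is 3000 nM, with a range from 1000 nM to 9000 nM.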

Compound 4, half-maximal inhibitory concentration: 3600 nM
Beside the measured number, compound 4's estimate is 1.2-fold (0.08 log units) below it; low and high end bracket the measured number.
By their numbers in this assay, from the lowest: compounds 1, 4, 2 and 3 (each within the scatter of the next, the first and the last beyond it).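

In this assay, the swap from phenyl to 4-chlorophenyl can now be read directly, with hexyl held on the ring nitrogen: chloro in place of hydrogen on the aromatic carbon gives a 1.3-fold lower number from compound 3 to compound 4 (0.10 log units; within the scatter), so this position accepts chloro with no shift that can be resolved. With 4-chlorophenyl held, the group on the ring nitrogen can also be compared across three sizes: hexyl in place of cyclopropyl gives a 1.1-fold lower number from compound 2 to compound 4 (0.05 log units; within the scatter), and hexyl in place of methyl gives a 1.8-fold higher number from compound 1 to compound 4 (0.26 log units; within the scatter), so neither change separates from the scatter. Nothing available bears on why these steps are small.

As far as these compounds go, whether the chloro step stays this small with methyl or cyclopropyl on the ring nitrogen remains open, as only the hexyl pair reads that change alone. Also open, from the compounds shown here alone, is whether a different group at this aromatic position, such as methoxy or a carboxylic acid, or a longer chain or an amine on the ring nitrogen, would move the number beyond the scatter.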